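A Chlorophenyl Replaces a Dimethylphenyl on a Ring Amine

The source may report more compounds than this note shows. Statements on the series, on what has been measured and on what is new or still open speak of the compounds shown alone.

compound 1 `Cc1nc(-c2ccccc2)c(C(=O)N2CCN(c3c(C)cccc3C)CC2)o1` — 146 nM
compound 2 `COc1ccc(-c2nc(C)oc2C(=O)N2CCN(c3cccc(Cl)c3)CC2)cc1O` — "not active" (no number reported)
compound 3 `COc1cc(OC)cc(N2CCN(C(=O)c3sc(C)nc3-c3ccccc3F)CC2)c1` — 96.8 nM

Of the compounds shown here, three have been measured in a functional assay on HL-60 cells (Homo sapiens) for inhibition, read by MTT assay, with a stated time of 72 h; a higher number here means a weaker inhibitor, a lower number a stronger inhibitor. Compound 1 gives 146 nM, the higher of the two reported numbers. Compound 3 gives 96.8 nM, which lies within the usual scatter of compound 1, so the two cannot be told apart. Compound 2 is reported as not active, with no number. Compound 4 `Cc1nc(-c2ccccc2)c(C(=O)N2CCN(c3ccccc3Cl)CC2)o1` has not yet been measured. It differs from compound 1 in one place: 2-chlorophenyl in place of 2,6-dimethylphenyl on an amine nitrogen in a ring. Among the measured compounds shown here, no measured pair shows this change by itself, so its effect is unknown. The step from compound 1 to compound 4 is expected to be a 1.7-fold higher number from compound 1 to compound 4 (0.23 log units; within the scatter), small and toward a weaker inhibitor, hardly beyond the scatter. Compound 4 is thus expected to give 250 nM in this assay, within a range from 80 nM to 800 nM.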

Compound 4, half-maximal inhibitory concentration: 124 nM
Compound 4: the middle estimate sits 2.0-fold (0.30 log units) above what was measured; the measured number falls inside the stated range.
By their numbers in this assay, from the lowest: compounds 3, 4 and 1 (each within the scatter of the next).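

In this assay, 2-chlorophenyl in place of 2,6-dimethylphenyl on the ring amine nitrogen gives a 1.2-fold lower number from compound 1 to compound 4 (0.07 log units; within the scatter) and so leaves the two compounds indistinguishable. Among the compounds shown here, this is the first pair here that isolates this position, and it shows that the two groups can be exchanged there with no readable effect on the number. No measurement at hand explains this match. The compounds shown leave open whether a group without a phenyl ring, such as a longer chain or one ending in a carboxylic acid, would be tolerated at this nitrogen.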